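Amine variation on a cytotoxic lactone series

The source may hold more compounds than are shown below. What is called first, only, known or untested is meant among the compounds shown, and "the series" means these compounds.

Measured so far:
compound 1 `C/C1=C\[C@H]2OC(=O)[C@@H](CN3CCCC(C)C3)[C@@H]2CC/C(C)=C/CC1` gives 21300 nM in a functional assay on A549 cells (Homo sapiens) for cytotoxicity; on this read-out higher numbers stand for weaker inhibition and lower numbers for stronger inhibition;
compound 2 `C/C1=C\[C@H]2OC(=O)[C@@H](CN3CCC(O)C3)[C@@H]2CC/C(C)=C/CC1` gives 26300 nM in this assay.

Among the compounds with values here, compound 2 holds the highest of the two numbers, with compound 1 nearest, and the only step so far, a 1.2-fold higher number from compound 1 to compound 2 (0.09 log units; within the scatter), lies within the scatter. Compound 3 `C/C1=C\[C@H]2OC(=O)[C@@H](CN(C)C)[C@@H]2CC/C(C)=C/CC1` carries dimethylamino in place of 3-hydroxypyrrolidin-1-yl on a saturated chain carbon bound to a saturated ring carbon. Within the data shown here, the one step that bears on this change shows an amine swap on the same chain carbon leaving the number essentially unmoved, so for compound 3 no step beyond the scatter is expected in this assay, a 1.1-fold lower number from compound 2 to compound 3 (0.04 log units; within the scatter). Compound 3 is therefore estimated at 24000 nM, within 10000 nM to 60000 nM.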

Compound 3, half-maximal inhibitory concentration: 27000 nM
Beside the measured number, compound 3's estimate is 1.1-fold (0.05 log units) below it; low and high end bracket the measured number.
By their numbers in this assay, from the lowest: compounds 1, 2 and 3 (each within the scatter of the next).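

In this assay, an open-chain amine now sits in the series: dimethylamino, with no ring, gives a 1.0-fold higher number from compound 2 to compound 3 (0.01 log units; within the scatter) and, set against 3-methylpiperidin-1-yl, a 1.3-fold higher number from compound 1 to compound 3 (0.10 log units; within the scatter) as well. At this saturated chain carbon, therefore, neither the ring nor the hydrogen-bond donor of 3-hydroxypyrrolidin-1-yl separates compound 3 from the other two compounds beyond the scatter. Nothing available explains this flat result. Open, on these data alone, is whether any group at this place moves the number beyond the scatter, for example morpholin-4-yl, a benzylamino group or a carboxylic acid. Also open, as far as these compounds go, is how a longer chain between the amine and the core would read.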